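The source may hold more compounds than are shown below. What is called first, only, known or untested is meant among the compounds shown, and "the series" means these compounds.

For the measured compounds named here, compound 1 `COc1cc(C(=O)c2sc(N)nc2N)cc(OC)c1OC` holds the higher of the two numbers so far in a functional assay on CCRF-CEM cells (Homo sapiens) for antiproliferative activity, read by cell counting, with a stated time of 2 days (a lower number here means a stronger inhibitor, a higher number a weaker inhibitor), where compound 1 gives 42000 nM. Compound 2 `COc1cc(C(=O)c2sc(N(C)C)nc2N)cc(OC)c1OC` gives 11000 nM in this assay; that step, a 3.8-fold lower number from compound 1 to compound 2 (0.58 log units; beyond the scatter), came from dimethylamino in place of amino on an aromatic carbon. Compound 3 `COc1cc(C(=O)c2sc(N3CCCCC3)nc2N)cc(OC)c1OC` differs from compound 1 by piperidin-1-yl in place of amino on an aromatic carbon. Going by the values given here, only the step to compound 2 bears on this change, and it was modest, so a step of similar size and in the same direction is expected for compound 3, a 5.3-fold lower number from compound 1 to compound 3 (0.72 log units; beyond the scatter). Compound 3 is estimated at 8000 nM, within a range of 3000 nM to 25000 nM.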

Compound 3, half-maximal inhibitory concentration: 22000 nM
The estimate for compound 3 lay 2.8-fold (0.44 log units) below the measured number, within the range that was stated.
By their numbers in this assay, from the lowest: compounds 2, 3 and 1 (each within the scatter of the next, the first and the last beyond it).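

In this assay, piperidin-1-yl on this aromatic carbon, next to the ring nitrogen and the ring sulfur, cannot be told apart from amino, with a 1.9-fold lower number from compound 1 to compound 3 (0.28 log units; within the scatter), or from dimethylamino, with a 2.0-fold higher number from compound 2 to compound 3 (0.30 log units; within the scatter). The position therefore still gives a readable number with a group of 6 heavy atoms that has no hydrogen-bond donor, but this larger ring brings no clear gain over either smaller group. No measurement here offers an explanation for this result. Still open, going by these compounds, is how an open chain such as diethylamino would compare, or a ring carrying a second hetero atom, such as morpholin-4-yl.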